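Amino to nitro, starting from an assay limit

The source may report more compounds than this note shows. Statements on the series, on what has been measured and on what is new or still open speak of the compounds shown alone.

In a functional assay on A549 cells (Homo sapiens) for antiproliferative activity, read by MTT assay, with a stated time of 72 h (a higher number here means a weaker inhibitor, a lower number a stronger inhibitor), compound 1 (`COc1cc(-c2ncnn2-c2cccc(N)c2)cc(OC)c1OC`) gives > 10000 nM as its result, which is a limit and not a number. Compound 2 (`COc1cc(-c2ncnn2-c2ccc(N)cc2)cc(OC)c1OC`) gives > 10000 nM as its result, again a limit. Within the data shown here, the only measured step is a step that the two limits leave unreadable from compound 1 to compound 2 and so offers no size to carry over. The available evidence amounts to the limit of > 10000 nM in this assay, at which 2 of the 2 values shown sit, and gives no numerical potency for either compound. Compound 3 (`COc1cc(-c2ncnn2-c2cccc([N+](=O)[O-])c2)cc(OC)c1OC`) differs from compound 1 by one change: nitro in place of amino on an aromatic carbon with the nitro group meta to a large group. With no readable step to guide it, no clear movement in this assay is expected, and a result at the limit is the likeliest outcome. The estimate means a step that the limit leaves unreadable from compound 1 to compound 3 as the expected step. Compound 3 is expected at about 12000 nM in this assay. Its estimated range runs from 3000 nM to 40000 nM as a cautious span.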

Compound 3, half-maximal inhibitory concentration: > 10000 nM
Compound 3: only a limit was reported; the forecaster's own chance of this, stated with the estimate: 75%; the middle value is on the limit's open side.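

Compound 3, like compound 1 and compound 2, returned only a limit in this assay, so no step among these compounds can be read, and nitro in place of amino has no size here: the limit of > 10000 nM in this assay, at which 3 of the 3 values shown sit.

The compounds shown leave open what numerical potency, if any, this series reaches in this assay.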